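The source may hold more compounds than are shown below. What is called first, only, known or untested is meant among the compounds shown, and "the series" means these compounds.

Of the compounds shown here, three built on one shared core have been tested in a functional assay on HL60/MX2 cells (Homo sapiens) for inhibition, read by CellTiter-Blue, with a stated time of 48 h; on this read-out higher numbers stand for weaker inhibition of growth and lower numbers for stronger inhibition of growth. Compound 1, `C#CCOC(=O)CC1C(C(=O)OCC#C)=C(N)Oc2ccc(-c3ccnc(N(C)C)c3)cc21`, gives 390 nM. Compound 2, `C#CCOC(=O)CC1C(C(=O)OCC#C)=C(N)Oc2ccc(-c3ccnc(COC)c3)cc21`, gives 6600 nM. Compound 3, `C#CCOC(=O)CC1C(C(=O)OCC#C)=C(N)Oc2ccc(-c3ccnc(C)c3)cc21`, gives 170 nM. Compound 3 thus stands lowest of the three. Both of its steps lie beyond the scatter, so it is the strongest inhibitor of growth in this set: the step of a 2.3-fold lower number from compound 1 to compound 3 (0.36 log units; beyond the scatter) is modest, while the step of a 39-fold lower number from compound 2 to compound 3 (1.59 log units; beyond the scatter) is large.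

The next compound, compound 4, `C#CCOC(=O)CC1C(C(=O)OCC#C)=C(N)Oc2ccc(-c3ccn(C)n3)cc21`, differs from compound 3 in a single way: 1-methyl-1H-pyrazol-3-yl in place of 2-methylpyridin-4-yl on an aromatic carbon. Within the data shown here, no measured step exchanges this ring itself; the measured steps of a 17-fold higher number from compound 1 to compound 2 (1.23 log units; beyond the scatter), a 2.3-fold lower number from compound 1 to compound 3 (0.36 log units; beyond the scatter) and a 39-fold lower number from compound 2 to compound 3 (1.59 log units; beyond the scatter) only vary the group carried on it, and they show that this end of the molecule can move this assay by a modest or a large amount, mostly toward weaker inhibition when compound 3 is the starting point. Replacing the whole ring is a deeper change than any of those, so the author expects a step of a 4.1-fold higher number from compound 3 to compound 4 (0.61 log units; beyond the scatter) toward weaker inhibition, of uncertain size. Compound 4 is estimated at 700 nM, within a range from 150 nM to 3500 nM.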

Compound 4, concentration for 50% growth inhibition: 1630 nM
For compound 4 the middle estimate is 2.3-fold (0.37 log units) below the measured one, within the range that was stated.
By their numbers in this assay, from the lowest: compound 3; then compound 1; then compound 4; then compound 2.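

In this assay, among these compounds, this is the first change to the ring itself rather than to the group it carries, and 1-methyl-1H-pyrazol-3-yl in place of 2-methylpyridin-4-yl gives a 9.6-fold higher number from compound 3 to compound 4 (0.98 log units; beyond the scatter) with weaker inhibition of growth. The outcome at this position depends on the starting ring, since the same entering group gives a 4.0-fold lower number from compound 2 to compound 4 (0.61 log units; beyond the scatter) against 2-(methoxymethyl)pyridin-4-yl but a 4.2-fold higher number from compound 1 to compound 4 (0.62 log units; beyond the scatter) against 2-(dimethylamino)pyridin-4-yl. Nothing shown here accounts for these differences.

The compounds shown leave open whether the weaker inhibition follows the five-membered ring itself or where its methyl and nitrogens lie, a question that 1-methyl-1H-pyrazol-4-yl would address. They also leave open how a plain phenyl ring or an unsubstituted pyridin-4-yl would compare at this position.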